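A Halogen Swap Sitting at the Assay Limit

The source may hold more compounds than are shown below. What is called first, only, known or untested is meant among the compounds shown, and "the series" means these compounds.

Compound 1 `Nc1ncnc2c1c(F)cn2[C@@H]1C=C(CO)[C@@H](O)[C@H]1O` and compound 2 `Nc1ncnc2c1c(Cl)cn2[C@@H]1C=C(CO)[C@@H](O)[C@H]1O` share one core and differ only in a halogen. In an ADME assay on HepG2 2.2.15 cells (Homo sapiens) for cytotoxicity, read by neutral red uptake, with a stated time of 24 h (on this read-out lower numbers stand for stronger inhibition and higher numbers for weaker inhibition), compound 1 gives > 300000 nM, which is a limit of the assay and not a number. Compound 2 gives > 300000 nM, and this too is only a limit. So far, the data show (the limit of > 300000 nM in this assay, at which 2 of the 2 values shown sit). Compound 3 `Nc1ncnc2c1c(Br)cn2[C@@H]1C=C(CO)[C@@H](O)[C@H]1O` has bromo in place of chloro on an aromatic carbon. Going by the values given here, the closest guide is the one measured halogen swap, a step that the two limits leave unreadable from compound 1 to compound 2. It offers no size to carry forward, so no change beyond the scatter is expected in this assay, in either direction. The expected step is a number no higher from compound 2 to compound 3 (the limit leaves the size open). For compound 3, the estimated value is 300000 nM, with an expected range from 120000 nM to 500000 nM, and another limit is the likeliest report.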

Compound 3, half-maximal inhibitory concentration: > 300000 nM
Compound 3 ended at the assay's limit; the forecaster's own chance of this, stated with the estimate: 80%; the middle value lies on the limit itself.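

No new step can be read among compound 1, compound 2 and compound 3, whose results in this assay are all limits of the assay and not numbers: the limit of > 300000 nM in this assay, at which 3 of the 3 values shown sit. From the compounds shown here alone, whether fluoro, chloro and bromo differ at all on the shared core remains open.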